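Hydroxamic acid to 2-aminophenyl amide on a shared core

The source may hold more compounds than are shown below. What is called first, only, known or untested is meant among the compounds shown, and "the series" means these compounds.

Three compounds share one core and differ in the tether to the benzamide. In an assay on isolated protein for inhibition of protein deacetylase HDAC6 (Homo sapiens), with a stated time of 15 min (a lower number here means a stronger inhibitor, a higher number a weaker inhibitor), compound 1 `Nc1nc(NCc2ccc(C(=O)NO)cc2)nc2nc(-c3ccco3)nn12` gives 3 nM, compound 3 `Nc1nc(NCCOc2ccc(C(=O)NO)cc2)nc2nc(-c3ccco3)nn12` gives 3.2 nM, and compound 2 `Nc1nc(NCCCc2ccc(C(=O)NO)cc2)nc2nc(-c3ccco3)nn12` gives 4.9 nM. Compound 2 carries the highest of the three numbers, but its gap to compound 3 and its gap to compound 1 both lie within the usual scatter, so the three cannot be told apart on these figures.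

Compound 4 `Nc1ccccc1NC(=O)c1ccc(CCCNc2nc(N)n3nc(-c4ccco4)nc3n2)cc1` keeps the three-carbon tether of compound 2 and changes the far end: 2-aminophenyl in place of hydroxy on an amide-type nitrogen. No such change has been measured within this set, and the tether variations seen so far give no guide to it, since every one of them left the hydroxycarbamoyl group in place.

The change is expected to cost potency, and by a wide margin rather than within the scatter. For compound 4 the step from compound 2 is estimated at a 410-fold higher number from compound 2 to compound 4 (2.61 log units; beyond the scatter) in this assay. Compound 4 is therefore expected to give about 2000 nM, with a likely range from 300 nM to 20000 nM.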

Compound 4, half-maximal inhibitory concentration: > 10000 nM
Compound 4 was reported as a limit; the forecaster's own chance of this, stated with the estimate: 20%; middle value at least 5.0-fold (0.69 log units) away from the limit.
By their numbers in this assay, from the lowest: compounds 1, 3 and 2 (each within the scatter of the next). At a limit, above all of these: compound 4.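

In this assay, compound 4 gives > 10000 nM, which is a limit of the assay and not a number. The change on the amide-type nitrogen amounts to an at least 2000-fold higher number from compound 2 to compound 4 (3.30 log units; beyond the scatter), the first step in this set to lie beyond the scatter, whereas the three tether variants, which all keep the hydroxycarbamoyl group, could not be told apart, so this far end of the molecule matters much more than the tether among the compounds shown. The step can be read only as a lower bound, and the true number for compound 4 remains unknown: the limit of > 10000 nM in this assay, at which 1 of the 4 values shown sits.

The compounds shown leave open whether a smaller group on that nitrogen, such as methyl or a plain amine, or a carboxylic acid in place of the hydroxycarbamoyl group, would keep any of the potency of compound 2. They also leave open whether the (2-aminophenyl)carbamoyl group would fare the same on the tethers of compound 1 and compound 3, and how it would behave against any other deacetylase.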